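The source may report more compounds than this note shows. Statements on the series, on what has been measured and on what is new or still open speak of the compounds shown alone.

In a physicochemical assay for solubility (on this read-out lower numbers stand for lower solubility and higher numbers for higher solubility), the measured compounds are:
Compound 1 `O=C(c1ccccn1)N1CCC(NS(=O)(=O)c2cc(S(=O)(=O)c3ccccc3)ccc2C(F)(F)F)CC1` with 100000 nM
Compound 2 `O=C(O)c1ccc(N2CCC(NS(=O)(=O)c3cc(S(=O)(=O)c4ccccc4)ccc3C(F)(F)F)CC2)cc1` with 25000 nM

Compound 2 stands lowest of the two at 25000 nM. Compound 3 `CC(C)(O)CCN1CCC(NS(=O)(=O)c2cc(S(=O)(=O)c3ccccc3)ccc2C(F)(F)F)CC1` differs from it as follows: 3-hydroxy-3-methylbutyl in place of 4-carboxyphenyl on an amine nitrogen in a ring. In words, 3-hydroxy-3-methylbutyl sits in place of 4-carboxyphenyl on an amine nitrogen in a ring. Going by the values given here, one measured step bears on this change, a modest one at the same nitrogen: a 4.0-fold lower number from compound 1 to compound 2 (0.60 log units; beyond the scatter). That step brought in the group now leaving, but the entering group is a different one, so it is only a rough guide. A step of similar or smaller size toward higher numbers is expected in this assay. The estimated step is a 2.4-fold higher number from compound 2 to compound 3 (0.38 log units; beyond the scatter). Compound 3 is estimated at 60000 nM, with an expected range from 22000 nM to 150000 nM.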

Compound 3, solubility: 50000 nM
The estimate for compound 3 lay 1.2-fold (0.08 log units) above the measured number; the range from low to high includes it.
By their numbers in this assay, from the lowest: compounds 2, 3 and 1 (each within the scatter of the next, the first and the last beyond it).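

At this amine nitrogen in a ring, this assay now covers a third group, 3-hydroxy-3-methylbutyl, which has no ring. Replacing 4-carboxyphenyl with it gives a 2.0-fold higher number from compound 2 to compound 3 (0.30 log units; within the scatter) and replacing (pyridin-2-yl)carbonyl with it gives a 2.0-fold lower number from compound 1 to compound 3 (0.30 log units; within the scatter). Compound 3 thus lies within the scatter of both earlier compounds, although those two lie beyond it from each other. Nothing available here explains this result. The compounds shown leave open how a carboxylic acid on an open chain or a simple amine at this nitrogen would read in this assay.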